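The source may hold more compounds than are shown below. What is called first, only, known or untested is meant among the compounds shown, and "the series" means these compounds.

Measured compounds in a functional assay on the whole organism (strain ICR) for inhibition, with Mus musculus as the target, read by scintillation counting, with a stated time of 16 h, at a dose of 10 mg/kg by the oral route; a higher number here means more inhibition at the dose given (going by the name of the read-out), a lower number less inhibition:
compound 1, `Cn1c(-c2ccc(-c3cncnc3)cc2)nnc1C1(c2ccc(Cl)cc2)CCC1`, gives -4%
compound 2, `CC(=O)Nc1ccc(-c2nnc(C3(c4ccc(Cl)cc4)CCC3)n2C)c(Cl)c1`, gives 27%
compound 3, `Cn1c(-c2ccc(-c3cnccn3)cc2F)nnc1C1(c2ccc(Cl)cc2)CCC1`, gives 81%

Three compounds share a common core and differ in the group attached to one end of it. Among them compound 1 stands lowest in this assay: its number is the smallest of the three, and both gaps, to compound 2 and to compound 3, are larger than the usual scatter of repeated measurements, so compound 1 shows essentially no inhibition under these conditions while compound 3 shows a great deal.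

The next compound, compound 4, `CCNC(=O)c1ccc(-c2nnc(C3(c4ccc(Cl)cc4)CCC3)n2C)cc1`, has not yet been measured in this assay. It is derived from compound 1 by a single change: ethylcarbamoyl in place of pyrimidin-5-yl on an aromatic carbon. A flat aromatic group with two ring nitrogens is thus replaced by a short open-chain amide carrying one hydrogen-bond donor.

Among the compounds with values here, no measured pair differs in exactly one place, so there is no direct precedent for the size of such a step. Starting from the lowest value, there is room for an increase, and the other two compounds show that this core can reach clearly higher numbers. The step of a number 29 percentage points higher from compound 1 to compound 4 (beyond the scatter) is therefore expected to be upward and moderate, rather than none. Compound 4 is expected to give about 25%, with a range from -5% to 55%.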

Compound 4, a percentage reported as inhibition, in the whole organism at one dose (the size of the read-out at that dose, not a potency): 0%
Compound 4: the middle estimate sits 25 percentage points above what was measured; measured number inside the range.
By their numbers in this assay, from the lowest: compounds 1 and 4 (each within the scatter of the next); then compound 2; then compound 3.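

In this assay, ethylcarbamoyl in place of pyrimidin-5-yl, on an aromatic carbon para to a large group, gives a number 4 percentage points higher from compound 1 to compound 4 (within the scatter). Within the data shown here, this is the first reading of a single change at this position, and at this dose the two groups cannot be told apart. An aromatic ring with two ring nitrogens and an open-chain amide with one hydrogen-bond donor thus lead to the same outcome within the scatter, with compound 1 at -4% and compound 4 at 0%, and no accompanying measurement offers an explanation for this.

The compounds shown leave open whether any group at this position, on this otherwise unchanged core, can lift the read-out clearly above that of compound 1, since this single pair covers only two groups. A carboxylic acid, a primary amine or a longer chain on the amide nitrogen could each test this, and a second dose would show whether the two groups also match when more or less compound is given.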